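A shorter nitrile chain on the shared core

The source may report more compounds than this note shows. Statements on the series, on what has been measured and on what is new or still open speak of the compounds shown alone.

Compound 1 `COc1ccc(-c2cc3cccc(OC)c3nc2O)cc1` gives 10000 nM as its reading
Compound 2 `CCN(CC)C(=O)Cn1c(=O)c(-c2ccc(OC)cc2)cc2c(OC)cc(OC)cc21` gives 10000 nM as its reading
Compound 3 `COc1ccc(-c2cc3c(OC)cc(OC)cc3n(CCCC#N)c2=O)cc1` gives 10000 nM as its reading

In a functional assay on U-87MG ATCC cells for cytotoxicity against U-87 MG (Homo sapiens), read by colorimetric assay and MTT assay (a lower number here means a stronger inhibitor, a higher number a weaker inhibitor), compound 3 stands at 10000 nM and so sits level with compound 1 and compound 2. Compound 4 `COc1ccc(-c2cc3c(OC)cc(OC)cc3n(CCC#N)c2=O)cc1` differs from it in one place: cyano in place of cyanomethyl on a saturated chain carbon, two bonds along the chain from an aromatic nitrogen with cyano in place of cyanomethyl on a saturated chain carbon, two bonds along the chain from an aromatic nitrogen. Among the measured compounds shown here, one measured step touches this same chain: no change at the digits printed from compound 2 to compound 3 (within the scatter) and that is the only guide, a thin one. No shift beyond the scatter is therefore expected in this assay here. The expected step is no change at the digits printed from compound 3 to compound 4 (within the scatter) as an estimate. Compound 4 is estimated at 10000 nM with an expected range from 4000 nM to 20000 nM around that figure.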

Compound 4, half-maximal inhibitory concentration: 10000 nM
Compound 4: middle estimate and measured number agree at the digits printed, and the stated range covers the measured number.
By their numbers in this assay, from the lowest: compounds 1, 2, 3 and 4 (each within the scatter of the next).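

In this assay, going from 3-cyanopropyl to 2-cyanoethyl on the aromatic nitrogen gives no change at the digits printed from compound 3 to compound 4 (within the scatter), so this shorter nitrile chain leaves the reading where it was. Swapping diethylcarbamoyl for cyanomethyl on the saturated chain carbon bound to that nitrogen likewise gives no change at the digits printed from compound 2 to compound 4 (within the scatter), so two quite different groups at this position read alike. No measurement here bears on why these readings match. Still open, as far as these compounds go, is whether a chain ending in an amine or a carboxylic acid, or a longer nitrile chain, would move the reading.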